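Swapping 4-Ethoxyphenyl for 2-Ethoxyphenyl in Compound 4

This account rests on a few compounds, and the source may have more. Where it says the series, first, only, none or still open, it means among the compounds named here.

Compound 1 `CCOc1ccccc1-n1nncc1CN1C(=O)C2(C(C#N)=C(N)Oc3c2c2nc4ccccc4nc2c2ccccc32)c2ccccc21`: in a functional assay on A549 cells (Homo sapiens) for antiproliferative activity, read by MTT assay, with a stated time of 48 h (a higher number here means a weaker inhibitor, a lower number a stronger inhibitor), compound 1 reaches only the assay limit > 50000 nM.
Compound 2 `CCOc1ccc(-n2nncc2CN2C(=O)C3(C(C#N)=C(N)Oc4c3c3nc5ccccc5nc3c3ccccc43)c3ccccc32)cc1`: in this assay compound 2 gives 25200 nM.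
Compound 3 `CCOc1ccc(-n2nncc2CN2C(=O)C3(C(C#N)=C(N)Oc4c(N)cc5nc6ccccc6nc5c43)c3ccccc32)cc1`: in this assay compound 3 reaches only the assay limit > 50000 nM.

Compound 4 `CCOc1ccccc1-n1nncc1CN1C(=O)C2(C(C#N)=C(N)Oc3c(N)cc4nc5ccccc5nc4c32)c2ccccc21` has not yet been measured. It differs from compound 3 by 2-ethoxyphenyl in place of 4-ethoxyphenyl on an aromatic nitrogen. The measured pair shows the same change, (2-ethoxyphenyl in place of 4-ethoxyphenyl on an aromatic nitrogen), which gave an at least 1.9-fold higher number from compound 2 to compound 1 (0.29 log units; that floor lies within the scatter). How the core of compound 3 differs from that of compound 2 is not broken down here. Two of the three values sit at the limit (the limit of > 50000 nM in this assay, at which 2 of the 3 values shown sit), and compound 3 is one of them, so a step in the same direction cannot lower the number. Compound 4 is therefore expected to stay beyond the limit, with an estimated step that the limit leaves unreadable from compound 3 to compound 4. The estimate for compound 4 in this assay is 80000 nM.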

Compound 4, half-maximal inhibitory concentration: > 50000 nM
Compound 4: only a limit was reported; the forecaster's own chance of this, stated with the estimate: 90%; the middle value is on the limit's open side.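

No step can be read from compound 3 to compound 4, since in this assay each reaches only a limit: the limit of > 50000 nM in this assay, at which 3 of the 4 values shown sit.

The compounds shown leave open how far past that limit either compound lies, and whether 2-ethoxyphenyl in place of 4-ethoxyphenyl changes anything on this core.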